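This account rests on a few compounds, and the source may have more. Where it says the series, first, only, none or still open, it means among the compounds named here.

Going by the values given here, in a functional assay on SW480 cells (Homo sapiens) for cytotoxicity, read by MTT assay, with a stated time of 4 days (a higher number here means a weaker inhibitor, a lower number a stronger inhibitor), compound 3 `C=C1C(=O)[C@]23C[C@@]1(O)CC[C@H]2c1ccc(OS(=O)(=O)c2ccc(C)cc2)c(C)c1[C@@H]3Cn1cc(-c2ccc(F)cc2)nn1` gives 1630 nM, the only number in this set. Compound 1 `C=C1C[C@]23C[C@@]1(O)CC[C@@H]2c1cccc(C)c1[C@@H]3Cn1cc(-c2ccc(C)cc2)nn1` reaches only a limit of the assay, > 20000 nM. Compound 2 `Cc1c(O)ccc2c1[C@H](Cn1cc(-c3ccc(F)cc3)nn1)[C@@]13CC(=O)[C@@](C)(CC[C@@H]21)C3` likewise stops at a limit, > 20000 nM. Among the compounds with values here, compound 3 therefore stands alone as the one compound with a measured value, the rest being (the limit of > 20000 nM in this assay, at which 2 of the 3 values shown sit). Compound 4 `C=C1C(=O)[C@]23C[C@@]1(O)CC[C@H]2c1ccc(OS(=O)(=O)c2ccc(C)cc2)c(C)c1[C@@H]3Cn1cc(-c2ccc(OC)cc2)nn1` has not yet been tested in this assay. It differs from compound 3 in one place: methoxy in place of fluoro on an aromatic carbon. Within the data shown here, no step between measured compounds exists to calibrate this change. The step from compound 3 to compound 4 is expected to be small, a 1.2-fold higher number from compound 3 to compound 4 (0.09 log units; within the scatter), within the usual scatter in either direction. Compound 4 is accordingly estimated at 2000 nM, with a range from 700 nM to 6000 nM.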

Compound 4, half-maximal inhibitory concentration: 1640 nM
Compound 4: middle estimate off by 1.2-fold (0.09 log units), on the high side; measured number inside the range.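

In this assay, the change from 4-fluorophenyl to 4-methoxyphenyl gives a 1.0-fold higher number from compound 3 to compound 4 (0.00 log units; within the scatter). Going by these compounds alone, this is the only step in the set that can be read, and it shows that methoxy in place of fluoro, on an aromatic carbon para to a large group, stays within the scatter. No measurement shown explains this result. On these data alone, whether an amine, a carboxylic acid or a longer chain at this place would also stay within the scatter remains open. The steps to compound 1 and compound 2 cannot be read.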